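From Methyl to Ethyl: Expecting Little Change

The source may hold more compounds than are shown below. What is called first, only, known or untested is meant among the compounds shown, and "the series" means these compounds.

Three compounds have numbers in a functional assay on HepG2 cells (Homo sapiens) for antiproliferative activity, read by MTT assay, with a stated time of 96 h; on this read-out higher numbers stand for weaker inhibition of growth and lower numbers for stronger inhibition of growth. Compound 1 (`Cc1cc(-c2ccc(F)cc2)nn1Cc1ccc(C(=O)NO)cc1`) gives 30000 nM and compound 3 (`O=C(NO)c1ccc(CNC(=O)c2cc(-c3ccc(F)cc3)[nH]n2)cc1`) gives 38100 nM, so these two lie within the usual scatter of each other. Compound 2 (`O=C(CCNC(=O)c1cc(-c2ccc(F)cc2)[nH]n1)NO`) gives 76000 nM, a higher number than compound 1 by more than the scatter, meaning weaker inhibition of growth. Compound 1 therefore stands at the low end of this small set, level with compound 3.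

Compound 4 (`CCc1cc(-c2ccc(F)cc2)nn1Cc1ccc(C(=O)NO)cc1`) differs from compound 1 in one place: methyl in place of hydrogen on a saturated chain carbon bound to an aromatic carbon. This is methyl in place of hydrogen on a saturated chain carbon bound to an aromatic carbon, which turns methyl into ethyl. Among the compounds with values here, no measured pair shows this change, so the data cannot size it directly. Starting from compound 1 at 30000 nM, no step beyond the scatter is expected in this assay, in either direction. The estimated step is a 1.1-fold lower number from compound 1 to compound 4 (0.05 log units; within the scatter), within the scatter. For compound 4 the expected value is 27000 nM, with an estimated range of 13000 nM to 55000 nM.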

Compound 4, concentration for 50% growth inhibition: 16700 nM
The estimate for compound 4 lay 1.6-fold (0.21 log units) above the measured number; the measured number falls inside the stated range.
By their numbers in this assay, from the lowest: compounds 4, 1, 3 and 2 (each within the scatter of the next, the first and the last beyond it).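

Within the data shown here, this is the first pair in the set that differs in one place, so the size of this change can now be read directly instead of estimated: in this assay, going from methyl to ethyl on a saturated chain carbon bound to an aromatic carbon gives a 1.8-fold lower number from compound 1 to compound 4 (0.25 log units; within the scatter). One added carbon at this position therefore does not separate the two compounds by more than repeated measurements would. Nothing measured here speaks to the reason for this result.

Going by these compounds, whether a longer chain such as propyl, a branched group such as isopropyl, or a carboxylic acid or an amine at this place would also stay level with methyl remains open. A single step from methyl to ethyl cannot show a trend along a series of chain lengths.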